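Two Amides at the Limit and a Third to Come

The source may hold more compounds than are shown below. What is called first, only, known or untested is meant among the compounds shown, and "the series" means these compounds.

Compound 1, `C=CC1=C(C(=O)NC2CCCCC2)C(c2ccc(OC)cc2)OC1`, was tested in a functional assay on SW480 cells (Homo sapiens) for cytotoxicity, read by MTT assay, with a stated time of 24 h; a lower number here means a stronger inhibitor, a higher number a weaker inhibitor. In that assay compound 1 returns only a limit, > 100000 nM. Compound 2, `C=CC1=C(C(=O)NCCC)C(c2ccc(OC)cc2)OC1`, likewise gives only a limit in this assay, namely > 100000 nM. The step that the two limits leave unreadable from compound 1 to compound 2 therefore cannot be read, and compound 2 stands, like compound 1, at the limit of > 100000 nM in this assay, at which 2 of the 2 values shown sit, with no number of its own to place it. Compound 3, `C=CC1=C(C(=O)NCc2ccccc2F)C(c2ccc(OC)cc2)OC1`, differs from compound 2 in one place: 2-fluorophenyl in place of ethyl on a saturated chain carbon bound to an amide-type nitrogen. Among the measured steps only the one from compound 1 to compound 2 sits on the same amide-type nitrogen, and its size is hidden by the two limits; so no measured step gives a reading for this change in this assay, and no direction can be taken from the numbers shown. The expectation for compound 3 is that it again sits at the limit, with a step that the limit leaves unreadable from compound 2 to compound 3 no larger than the scatter. Compound 3 is estimated at 150000 nM, between 40000 nM and 600000 nM.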

Compound 3, half-maximal inhibitory concentration: > 100000 nM
Compound 3 ended at the assay's limit; the forecaster's own chance of this, stated with the estimate: 80%; the middle value does not contradict the limit.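

Compound 3 gives only a limit in this assay, as do compound 1 and compound 2, so no step among the three can be read: the limit of > 100000 nM in this assay, at which 3 of the 3 values shown sit.

The compounds shown leave open whether cyclohexyl, propyl and 2-fluorobenzyl on the amide-type nitrogen differ at all in this assay, and at what concentration, if any, each compound would reach half-maximal inhibition.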